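Swapping butoxy for benzyloxy on compound 1

A few compounds are considered here, and "the series" means these few. Any claim that something is new, unique, unknown or untested is made for them only; others in the source may bear on it.

Measured so far in a functional assay on A-375 cells (Homo sapiens) for antiproliferative activity, read by trypan blue exclusion and crystal violet staining, with a stated time of 72 h; a higher number here means a weaker inhibitor, a lower number a stronger inhibitor:
- compound 1 `CCCCOc1ccnc2c(O)c(CNC(=O)C3CCCCC3)ccc12` gives 540 nM
- compound 2 `CCCC(=O)NC(c1ccc(C)cc1)c1cc(Cl)c2cccnc2c1O` gives 120 nM
- compound 3 `CCCC(=O)NC(c1ccc(Cl)cc1)c1cc(Cl)c2cccnc2c1O` gives 120 nM

Compound 1 has the highest number of the three, so it is the weakest, and its gap to compound 2 and to compound 3 lies beyond the scatter. Compound 4 `O=C(NCc1ccc2c(OCc3ccccc3)ccnc2c1O)C1CCCCC1` differs from compound 1 in one place, with phenyl in place of propyl on a saturated chain carbon bound to an oxygen on an aromatic ring, so butoxy becomes benzyloxy (phenyl in place of propyl on a saturated chain carbon bound to an oxygen on an aromatic ring). Within the data shown here, the only measured step shows no change at the digits printed from compound 2 to compound 3 (within the scatter) and it concerns chloro in place of methyl on an aromatic carbon, not this chain. Among the measured compounds shown here, no measured pair tests this swap, so no shift beyond the scatter is expected. In this assay compound 1 at 540 nM remains the anchor. The expected change is a 1.2-fold lower number from compound 1 to compound 4 (0.08 log units; within the scatter) and this estimate is uncertain. For compound 4 the estimated value is 450 nM with an expected range from 150 nM to 1300 nM as the likely span.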

Compound 4, half-maximal inhibitory concentration: 550 nM
The estimate for compound 4 lay 1.2-fold (0.09 log units) below the measured number; the measured number falls inside the stated range.
By their numbers in this assay, from the lowest: compounds 2 and 3 (each within the scatter of the next); then compounds 1 and 4 (each within the scatter of the next).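

In this assay, replacing butoxy with benzyloxy gives a 1.0-fold higher number from compound 1 to compound 4 (0.01 log units; within the scatter). At this position, on a saturated chain carbon bound to an oxygen on an aromatic ring, a phenyl ring with its six carbons therefore reads the same as a propyl group with three, which the step between compound 2 and compound 3 could not show. No measurement shown explains this match. Still open, going by these compounds, is whether a longer chain, or a chain ending in an amine or a carboxylic acid, would also leave the number within the scatter.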